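The compounds below may be only part of what the source reports. "The series", "measured", "known", "first", "only" and "open" are said of these compounds alone.

Compound 3 `COc1cc(-c2nn(-c3cccc(NC(=O)Nc4ccc(Cl)c(C(F)(F)F)c4)c3)cc2-c2ccncc2)ccc1Cl` is one of three close relatives measured in a functional assay on HCT-15 cells (Homo sapiens) for inhibition, read by sulforhodamine B assay, with a stated time of 48 h; a higher number here means a weaker inhibitor of growth, a lower number a stronger inhibitor of growth. Compound 1 `COc1cc(-c2nn(-c3cccc(NC(=O)Nc4cccc(C(F)(F)F)c4)c3)cc2-c2ccncc2)ccc1Cl` gives 5420 nM, and compound 3 gives 7050 nM, the highest of the two plain numbers shown, though the gap a 1.3-fold higher number from compound 1 to compound 3 (0.11 log units; within the scatter) lies within the scatter. Compound 2 `COc1cc(-c2nn(-c3cccc(NC(=O)c4ccc(Cl)c(C(F)(F)F)c4)c3)cc2-c2ccncc2)ccc1Cl` reaches only a limit of the assay, > 32500 nM, which is the limit of > 32500 nM in this assay, at which 1 of the 3 values shown sits.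

The next compound, compound 4 `COc1cc(-c2nn(-c3cccc(NC(=O)c4ccccc4)c3)cc2-c2ccncc2)ccc1Cl`, differs from compound 3 in one place: phenyl in place of (4-chloro-3-(trifluoromethyl)phenyl)amino on a carbonyl carbon. This turns a urea into a benzamide, the same kind of change that separates compound 1 from compound 2, and there the number rose by an at least 5.9-fold higher number from compound 1 to compound 2 (0.77 log units; beyond the scatter); in reverse, the step of an at least 4.6-fold lower number from compound 2 to compound 3 (0.66 log units; beyond the scatter) fell by a similar margin. Those steps therefore point to a clearly higher number in this assay for compound 4, and the number is expected to be a 4.3-fold higher number from compound 3 to compound 4 (0.63 log units; beyond the scatter). The estimate for compound 4 is 30000 nM, within a range from 10000 nM to 100000 nM.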

Compound 4, concentration for total growth inhibition: > 100000 nM
Compound 4 ended at the assay's limit (the forecaster's own chance of this, stated with the estimate: 50%); middle value at least 3.3-fold (0.52 log units) from the limit.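

In this assay, replacing the substituted phenylamino group of a urea with plain phenyl gives an at least 14-fold higher number from compound 3 to compound 4 (1.15 log units; beyond the scatter), and the same kind of change gives an at least 18-fold higher number from compound 1 to compound 4 (1.26 log units; beyond the scatter). Compound 4 sits at a limit of the assay, not at a measured number: the limit of > 100000 nM in this assay, at which 1 of the 4 values shown sits.

Compound 2 had already shown a benzamide at a limit, but it kept the chloro and trifluoromethyl groups, so compound 4 adds that a benzamide without them also falls far short of the ureas.

From the compounds shown here alone, compound 2 and compound 4 are both limits, so the step between them cannot be read, and any effect of chloro and trifluoromethyl on the benzamide stays unknown. Also open, going by these compounds, is whether a plain phenylamino group on the carbonyl carbon, with neither substituent, or a cyclohexylamino group there would keep the growth inhibition of the ureas.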